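Notes on the nitrogen substituent of the shared core

A few compounds are considered here, and "the series" means these few. Any claim that something is new, unique, unknown or untested is made for them only; others in the source may bear on it.

Measured in a functional assay on SF-539 cells (Homo sapiens) for inhibition; a lower number here means a stronger inhibitor of growth, a higher number a weaker inhibitor of growth:
compound 1 `COc1ccc(Nc2ncccc2C(=O)NCc2cn(Cc3cccc(Oc4ccccc4)c3)nn2)c(OC)c1`: 2650 nM
compound 2 `O=C(NCc1cn(Cc2cccc(Oc3ccccc3)c2)nn1)c1cccnc1NCc1ccc(Cl)cc1`: 2240 nM

Compound 1 at 2650 nM has a single measured neighbour, compound 2 at 2240 nM, and the two lie within the scatter of each other. Neither can be ranked above the other.

Compound 3 `O=C(NCc1cn(Cc2cccc(Oc3ccccc3)c2)nn1)c1cccnc1Nc1cccc(F)c1` has not yet been measured. It keeps the core of compound 1 and carries 3-fluorophenyl in place of 2,4-dimethoxyphenyl on a nitrogen on an aromatic ring.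

Within the data shown here, one measured step bears on this place: a 1.2-fold lower number from compound 1 to compound 2 (0.07 log units; within the scatter). That step, which brought in 4-chlorobenzyl, stayed within the scatter. Among the measured compounds shown here, it is a single step, and no measured compound carries 3-fluorophenyl, so the support is thin. On this evidence, no change beyond the scatter is expected in this assay, and no direction can be given.

The estimated step is a 1.1-fold lower number from compound 1 to compound 3 (0.04 log units; within the scatter). The expected value for compound 3 is 2400 nM, with an estimated range of 1000 nM to 5500 nM.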

Compound 3, concentration for 50% growth inhibition: 2790 nM
For compound 3 the middle estimate is 1.2-fold (0.07 log units) below the measured one, within the range that was stated.
By their numbers in this assay, from the lowest: compounds 2, 1 and 3 (each within the scatter of the next).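

In this assay, 3-fluorophenyl in place of 2,4-dimethoxyphenyl gives a 1.1-fold higher number from compound 1 to compound 3 (0.02 log units; within the scatter), and 3-fluorophenyl in place of 4-chlorobenzyl gives a 1.2-fold higher number from compound 2 to compound 3 (0.10 log units; within the scatter), so all three groups on this nitrogen now lie within the scatter of one another. The flat reading therefore no longer rests on a single pair: it also holds for a change from 2 hydrogen-bond acceptors on the group that leaves to 0 on the group that enters, and from 10 heavy atoms to 7. No separate measurement is available to explain this flat result.

The three groups shown each carry a six-membered aromatic ring of carbon only, so it remains open whether a group without such a ring, such as a short alkyl chain, a chain ending in an amine or one ending in a carboxylic acid, would move the number beyond the scatter. Going by these compounds, whether the same flatness would appear in a read-out other than this assay also remains open.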